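A Sulfonyl Swap Repeated on a Second Core

The compounds below may be only part of what the source reports. "The series", "measured", "known", "first", "only" and "open" are said of these compounds alone.

Compound 1 `CCS(=O)(=O)Nc1ccc(NC(=O)c2cc(C(F)(F)F)cc(C(F)(F)F)c2)cc1C` and compound 2 `Cc1cc(NC(=O)c2cc(C(F)(F)F)cc(C(F)(F)F)c2)ccc1NS(=O)(=O)C(F)(F)F` share one core and differ only in one place: trifluoromethyl in place of ethyl on a sulfonyl sulfur. In an ADME assay on RAW264.7 cells (Mus musculus) for cytotoxicity, read by MTT assay, with a stated time of 48 h (a lower number here means a stronger inhibitor, a higher number a weaker inhibitor), compound 1 gives 124000 nM, and compound 2 gives 40700 nM, so the change made a 3.0-fold lower number from compound 1 to compound 2 (0.48 log units; beyond the scatter). Compound 3 `CCS(=O)(=O)Nc1ccc(NC(=O)c2cccc(C(F)(F)F)c2)cc1F` is built on a different core; the difference between the two cores is not broken down here. In this assay compound 3 gives 119000 nM, a number within the scatter of compound 1. Compound 4 `O=C(Nc1ccc(NS(=O)(=O)C(F)(F)F)c(F)c1)c1cccc(C(F)(F)F)c1` differs from compound 3 by trifluoromethyl in place of ethyl on a sulfonyl sulfur, the same change at the same place as before. For the measured compounds named here, a similar step is expected, because the earlier step of a 3.0-fold lower number from compound 1 to compound 2 (0.48 log units; beyond the scatter) is the only guide here. The expected step is a 3.0-fold lower number from compound 3 to compound 4 (0.47 log units; beyond the scatter). Compound 4 is therefore estimated at 40000 nM, likely between 18000 nM and 90000 nM.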

Compound 4, half-maximal inhibitory concentration: 34400 nM
For compound 4 the middle estimate is 1.2-fold (0.07 log units) above the measured one; the measured number falls inside the stated range.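

The swap of ethyl for trifluoromethyl on the sulfonyl sulfur gave a 3.5-fold lower number from compound 3 to compound 4 (0.54 log units; beyond the scatter) in this assay, and the step carried over from the core of compound 1 to the core of compound 3 with its size kept: the same change on two cores in this assay, a 3.0-fold lower number (0.48 log units; beyond the scatter) from compound 1 to compound 2 and a 3.5-fold lower number (0.54 log units; beyond the scatter) from compound 3 to compound 4, 1.1-fold (0.06 log units) apart, within the scatter of two such steps. In this assay, then, the change behaved alike on both cores shown, but two cases make a match and not a rule for the whole series. This does not show why the number moves, or whether the step would hold on any further core or in another assay.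

The compounds shown leave open how a longer chain or an amine on the sulfonyl sulfur would compare. They also leave open whether the same swap would keep its size on a core carrying a carboxylic acid.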